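This account rests on a few compounds, and the source may have more. Where it says the series, first, only, none or still open, it means among the compounds named here.

Of the compounds shown here, three with a shared core have been measured in a functional assay on ECa-109 cells (Homo sapiens) for antiproliferative activity, read by MTT assay, with a stated time of 48 h; a higher number here means a weaker inhibitor, a lower number a stronger inhibitor. Compound 1 `Cn1cc(C2=C(c3nn(CCCN4CCCCC4)c4ncccc34)C(=O)N(c3ccc(Cl)cc3)C2=O)c2ccccc21` carries a chloro group on its aromatic ring and a 3-(piperidin-1-yl)propyl chain. In this assay compound 1 reaches only the limit of the assay, > 100000 nM, so no number is known for it. Compound 2 `COc1ccc(N2C(=O)C(c3cn(C)c4ccccc34)=C(c3nn(CCCN4CCCCC4)c4ncccc34)C2=O)cc1` has a methoxy in place of that chloro, and in this assay compound 2 gives 3340 nM. Among the compounds with values here, this is the single measured step, an at least 29-fold lower number from compound 1 to compound 2 (1.47 log units; beyond the scatter), and it rests on the limit (the limit of > 100000 nM in this assay, at which 1 of the 3 values shown sits). Within the data shown here, compound 3 `Cn1cc(C2=C(c3nn(CCCCn4ccnc4)c4ncccc34)C(=O)N(c3ccccc3)C2=O)c2ccccc21` carries an unsubstituted phenyl and a 4-(1H-imidazol-1-yl)butyl chain; in this assay compound 3 gives 7540 nM, the higher of the two numbers known, with compound 2 its nearest neighbour at a gap beyond the usual scatter.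

Compound 4 `Cn1cc(C2=C(c3nn(CCCN4CCCCC4)c4ncccc34)C(=O)N(c3ccccc3)C2=O)c2ccccc21` is compound 3 with one change: piperidin-1-yl in place of (1H-imidazol-1-yl)methyl on a saturated chain carbon, three bonds along the chain from an aromatic nitrogen. Among the measured compounds shown here, no measured step touches this chain; the only measured step concerns the aromatic ring and gives no guide here. Compound 4 does share its chain with compound 2, whose 3340 nM in this assay is lower than that of compound 3, but compound 2 also differs in its methoxy group. With so little to lean on, the step is expected to be small, a 1.7-fold lower number from compound 3 to compound 4 (0.22 log units; within the scatter). Compound 4 is therefore expected to give about 4500 nM, within 1500 nM to 15000 nM.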

Compound 4, half-maximal inhibitory concentration: 12300 nM
For compound 4 the middle estimate is 2.7-fold (0.44 log units) below the measured one; the measured number falls inside the stated range.
By their numbers in this assay, from the lowest: compound 2; then compounds 3 and 4 (each within the scatter of the next). At a limit, above all of these: compound 1.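

In this assay, the exchange of 4-(1H-imidazol-1-yl)butyl for 3-(piperidin-1-yl)propyl gives a 1.6-fold higher number from compound 3 to compound 4 (0.21 log units; within the scatter), so at this place on the chain, two quite different rings and chain lengths cannot be told apart in this pair. With the 3-(piperidin-1-yl)propyl chain held fixed, the aromatic ring now proves to matter more than this chain exchange: hydrogen in place of methoxy gives a 3.7-fold higher number from compound 2 to compound 4 (0.57 log units; beyond the scatter), which places the unsubstituted ring on the weaker side of the methoxy ring. Hydrogen in place of chloro gives an at least 8.1-fold lower number from compound 1 to compound 4 (0.91 log units; beyond the scatter), so the chloro ring lies on the weaker side of the unsubstituted ring, but this size is only a bound, as compound 1 stands at a limit: the limit of > 100000 nM in this assay, at which 1 of the 4 values shown sits.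

The exchange alters the ring and the chain length together, so a 3-(1H-imidazol-1-yl)propyl chain or a 4-(piperidin-1-yl)butyl chain would be needed to show whether either change has an effect alone, or whether two effects offset each other in this pair. From the compounds shown here alone, it also remains open where a morpholine at the chain end, or a fluoro or methyl group on the aromatic ring, would fall in this assay.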